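The source may report more compounds than this note shows. Statements on the series, on what has been measured and on what is new or still open speak of the compounds shown alone.

Working notes on the series. Of the compounds shown here, two have been measured in an ADME assay on HUVEC cells (Homo sapiens) for antiproliferative activity, read by MTT assay, with a stated time of 48 h (a higher number here means a weaker inhibitor, a lower number a stronger inhibitor), and one has not. Compound 1 `N#CC1=C(N)Oc2c(c3nc4ccccc4nc3c3ccccc23)C12C(=O)N(Cc1cnnn1-c1ccccc1Cl)c1ccccc12` is one of the measured pair. In this assay compound 1 gives > 50000 nM, which is a limit of the assay and not a number. Compound 2 `N#CC1=C(N)Oc2c(N)cc3nc4ccccc4nc3c2C12C(=O)N(Cc1cnnn1-c1ccc(Cl)cc1)c1ccccc12` carries a 4-chlorophenyl on an aromatic nitrogen of a five-membered aromatic ring with 3 nitrogen. In this assay compound 2 gives > 50000 nM, again a limit rather than a number. Among the compounds with values here, compound 2 thus stands at the limit of > 50000 nM in this assay, at which 2 of the 2 values shown sit; with both values shown sitting there, no step between measured compounds can be read, and no direction is known. Compound 3 `N#CC1=C(N)Oc2c(N)cc3nc4ccccc4nc3c2C12C(=O)N(Cc1cnnn1-c1cc(Cl)ccc1Cl)c1ccccc12` is the unmeasured one. Compared with compound 2 the change is 2,5-dichlorophenyl in place of 4-chlorophenyl on an aromatic nitrogen. Nothing measured here points either way, so the estimated step that the limit leaves unreadable from compound 2 to compound 3 is expected to be none beyond the scatter, most likely another limit. For compound 3 the estimate in this assay is 80000 nM, within a range from 35000 nM to 200000 nM.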

Compound 3, half-maximal inhibitory concentration: > 50000 nM
Compound 3: only a limit was reported (the forecaster's own chance of this, stated with the estimate: 85%); the middle value lies beyond the limit too.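

No step can be read from compound 2 to compound 3 in this assay, since both results are limits of the assay and not numbers: the limit of > 50000 nM in this assay, at which 3 of the 3 values shown sit.

The compounds shown leave open whether 2,5-dichlorophenyl in place of 4-chlorophenyl on an aromatic nitrogen changes the antiproliferative activity at all.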